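Removing the 4-methylphenyl group from compound 3

The source may hold more compounds than are shown below. What is called first, only, known or untested is meant among the compounds shown, and "the series" means these compounds.

Compound 3 `Cc1ccc(-c2cn(C[C@H](O)[C@H]3OC(=O)C(OCc4ccccc4)=C3OCc3ccccc3)nn2)cc1` carries a 4-methylphenyl group on the shared core. In a functional assay on CFPAC-1 cells (Homo sapiens) for antiproliferative activity, read by MTT assay, with a stated time of 72 h (a lower number here means a stronger inhibitor, a higher number a weaker inhibitor), compound 3 gives > 100000 nM, which is a limit of the assay and not a number. Two relatives give measured numbers: compound 1 `O=C1O[C@H]([C@@H](O)Cn2cc(CNS(=O)(=O)c3ccc(F)cc3)nn2)C(OCc2ccccc2)=C1OCc1ccccc1` gives 34700 nM and compound 2 `O=C1O[C@H]([C@@H](O)Cn2cc(C3CC3)nn2)C(OCc2ccccc2)=C1OCc1ccccc1` gives 47700 nM. Between these two, the data show a 1.4-fold higher number from compound 1 to compound 2 (0.14 log units; within the scatter).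

Compound 4 `C[Si](C)(C)c1cn(C[C@H](O)[C@H]2OC(=O)C(OCc3ccccc3)=C2OCc2ccccc2)nn1` differs from compound 3 in one place: a group of 4 heavy atoms (3 carbon, 1 silicon; no ring) in place of a group of 7 heavy atoms (7 carbon; one six-membered aromatic ring of carbon only), on an aromatic carbon. The entering group contains silicon and has no ring, and it sits on an aromatic carbon of the five-membered aromatic ring with 3 nitrogen.

Within the data shown here, two measured steps bear on this change, as both bring in the 4-methylphenyl group that compound 4 gives up. They are an at least 2.8-fold higher number from compound 1 to compound 3 (0.45 log units; beyond the scatter) and an at least 2.0-fold higher number from compound 2 to compound 3 (0.32 log units; beyond the scatter). Read backwards, they suggest that losing this group could lower the number. Among the measured compounds shown here, both are only minimum sizes, and no measured compound contains silicon, so the guidance is loose.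

A modest move toward a lower number in this assay is expected, estimated as an at least 1.6-fold lower number from compound 3 to compound 4 (0.22 log units; that floor lies within the scatter). A result that stays at the limit would not be surprising. The estimate for compound 4 is 60000 nM, with an expected range from 30000 nM to 100000 nM.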

Compound 4, half-maximal inhibitory concentration: 52600 nM
Compound 4: middle estimate off by 1.1-fold (0.06 log units), on the high side; the measured number falls inside the stated range.
By their numbers in this assay, from the lowest: compounds 1, 2 and 4 (each within the scatter of the next). At a limit, above all of these: compound 3.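

Putting the silicon-containing group in place of 4-methylphenyl gives an at least 1.9-fold lower number from compound 3 to compound 4 (0.27 log units; that floor lies within the scatter) in this assay, so this change brings a measured number, but its size cannot be separated from ordinary scatter. The new compound also adds to what the earlier pair showed, with a 1.1-fold higher number from compound 2 to compound 4 (0.04 log units; within the scatter) and a 1.5-fold higher number from compound 1 to compound 4 (0.18 log units; within the scatter), so on this aromatic carbon the silicon-containing group, cyclopropyl and (((4-fluorophenyl)sulfonyl)amino)methyl cannot be told apart in this test, even though the first has no ring and the other two do. Compound 3 remains the only one of the set reported as a limit of the assay and not as a number: the limit of > 100000 nM in this assay, at which 1 of the 4 values shown sits.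

As far as these compounds go, the true distance between compound 3 and the other three stays unknown, and so does whether silicon itself matters, a question that tert-butyl, the all-carbon counterpart of the entering group, would address directly. From the compounds shown here alone, it is also open whether an amine or a carboxylic acid on this aromatic carbon would move the number beyond the scatter of the three measured compounds.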